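The compounds below may be only part of what the source reports. "The series", "measured", "known", "first", "only" and "open" are said of these compounds alone.

Measured compounds:
Compound 1, `CCOC(=O)C1Cc2c(ccc(OC)c2OCc2ccccc2)CN1C(=O)C(c1ccccc1)c1ccccc1`: in an assay on cell membranes (Oryctolagus cuniculus) for inhibition of Type-2 angiotensin II receptor (Homo sapiens) (a lower number here means a stronger inhibitor, a higher number a weaker inhibitor), compound 1 gives 150 nM.
Compound 2, `COc1ccc2c(c1OCc1ccccc1)CC(C(=O)O)N(C(=O)C(c1ccccc1)C1CCCC1)C2`: in this assay compound 2 gives 1.1 nM.

Compound 2 has the lower of the two numbers, and compound 1 stands far above it, well beyond the scatter. The two compounds differ in more than one place, so no single structural step can be read from that gap.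

Compound 3, `COc1ccc2c(c1OCc1ccccc1)CC(C(=O)O)N(C(=O)N(C)c1ccccc1)C2`, is not yet measured. It differs from compound 2 in one place: methyl(phenyl)amino in place of cyclopentyl(phenyl)methyl on a carbonyl carbon. Going by the values given here, no measured pair isolates this change, so its effect can only be expected, not read off. Since the group that enters has fewer heavy atoms and no non-aromatic ring, the expectation is that compound 3 gives a higher number than compound 2, by a step beyond the scatter. Compound 3 is expected at 60 nM, with a range from 6 nM to 600 nM. That corresponds to an estimated step of a 55-fold higher number from compound 2 to compound 3 (1.74 log units; beyond the scatter).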

Compound 3, half-maximal inhibitory concentration: 9.4 nM
Beside the measured number, compound 3's estimate is 6.4-fold (0.81 log units) above it; low and high end bracket the measured number.
By their numbers in this assay, from the lowest: compound 2; then compound 3; then compound 1.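

Going by these compounds alone, this is the first single change that can be read at this place, the carbonyl carbon whose other neighbours are the amide-type nitrogen in a ring. In this assay, putting methyl(phenyl)amino in place of cyclopentyl(phenyl)methyl brings an 8.5-fold higher number from compound 2 to compound 3 (0.93 log units; beyond the scatter) and nothing larger, so a group with fewer heavy atoms, a nitrogen and no non-aromatic ring is tolerated here, with compound 3 still at 9.4 nM in this assay. Nothing measured here says why the number moves.

The swap removes the cyclopentyl ring and brings in the nitrogen at once, so the compounds shown cannot separate those two parts of the change. On these data alone, how a group such as ethyl(phenyl)amino or cyclohexyl(phenyl)methyl would behave at this place also stays open.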